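This account rests on a few compounds, and the source may have more. Where it says the series, first, only, none or still open, it means among the compounds named here.

Of the compounds shown here, three built on a shared core have been measured in an assay for inhibition of histone-lysine N-methyltransferase, H3 lysine-79 specific (Homo sapiens), read by scintillation counting, with stated times of 15 min and 60 min, tested at 100 uM, in the presence of a further agent that is not named here; on this read-out higher numbers stand for a stronger effect at the one concentration tested and lower numbers for a weaker effect. Compound 1 `Cc1occc1-c1nnc2sc(CCCc3ccccc3)nn12` gives 41%, compound 2 `C(=C/c1nn2c(-c3ccncc3)nnc2s1)\c1ccco1` gives 82%, and compound 3 `COc1ccccc1-c1nnc2sc(/C=C/c3ccco3)nn12` gives 78%. Compound 2 stands at the top of these three numbers, yet compound 3 lies within the usual scatter of it, so the two cannot be told apart, while compound 1 lies well beyond the scatter below both. Compound 4 `Fc1ccc(-c2nnc3sc(/C=C/c4ccco4)nn23)cc1` has not yet been measured. It differs from compound 2 in one place: 4-fluorophenyl in place of pyridin-4-yl on an aromatic carbon. Because compound 3 with a different aryl group gives 78% close to compound 2, the step of a number 7 percentage points lower from compound 2 to compound 4 (within the scatter) is expected to stay within the scatter. Compound 4 is therefore estimated at 75%, within 55% to 90%.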

Compound 4, a percentage reported as inhibition, at one concentration (the size of the read-out at that concentration, not a potency): 40%
Estimate against measurement, compound 4: 35 percentage points above; the whole stated range lies above it.
By their numbers in this assay, from the lowest: compounds 4 and 1 (each within the scatter of the next); then compounds 3 and 2 (each within the scatter of the next).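

Swapping pyridin-4-yl for 4-fluorophenyl on the aromatic carbon between two ring nitrogen atoms is a large step, a number 42 percentage points lower from compound 2 to compound 4 (beyond the scatter), so this position does not accept every aryl group alike. Compound 3, which also has a ring of carbon only here, gives 78%, so such a ring does not always go with a low number. Nothing measured here accounts for the drop. On these data alone, it remains open how plain phenyl, pyridin-3-yl or a morpholine at this position would compare with compound 2.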